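The source may report more compounds than this note shows. Statements on the series, on what has been measured and on what is new or still open speak of the compounds shown alone.

Compound 1 `Cc1cc(-n2ccc3ccncc32)ccc1C#N` sits in an assay on isolated protein for inhibition of Aromatase (Homo sapiens), read by fluorescence, tested at 1 uM (on this read-out higher numbers stand for more inhibition at the one concentration tested (going by the name of the read-out) and lower numbers for less inhibition), at the assay limit of > 99%, which is a limit rather than a number (the limit of > 99% in this assay, at which 1 of the 2 values shown sits). Going by the values given here, compound 2 `N#Cc1ccc(Oc2cccnc2)cc1Oc1cccc(Cl)c1` gives 25% in this assay and is the only compound of the pair with an actual number. Compound 3 `N#Cc1ccc(Oc2cccnc2)cc1Oc1cccnc1` differs from compound 2 by pyridin-3-yl in place of 3-chlorophenyl on an oxygen on an aromatic ring. Among the compounds with values here, no measured step of this kind exists, so the size of the step is open. The expected step from compound 2 to compound 3 in this assay is a number 20 percentage points higher from compound 2 to compound 3 (beyond the scatter), a gain beyond the scatter. Compound 3 is estimated at 45%, with a range from 15% to 80%.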

Compound 3, a percentage reported as inhibition, at one concentration (the size of the read-out at that concentration, not a potency): 81%
Compound 3: the middle estimate sits 36 percentage points below what was measured; the measured number lies above the stated range.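

At this place, on an oxygen on an aromatic ring, the group strongly affects the read-out in this assay: pyridin-3-yl in place of 3-chlorophenyl gives a number 56 percentage points higher from compound 2 to compound 3 (beyond the scatter). Going by these compounds alone, as the first measured step, it shows that the number in this assay is higher with pyridin-3-yl, a ring with one hetero atom, than with 3-chlorophenyl at this place. Nothing at hand gives a cause for this step.

Open, going by these compounds, is whether the ring nitrogen or the loss of chlorine carries the step; a plain phenyl on the same oxygen would separate the two. Also open, on these data alone, is whether the step holds with a group such as a methoxy in place of the other pyridin-3-yl.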